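A few compounds are considered here, and "the series" means these few. Any claim that something is new, unique, unknown or untested is made for them only; others in the source may bear on it.

Among the compounds with values here, compound 1 `Nc1sc(-c2ccc(Cl)cc2)c(-c2ccc(Cl)cc2)c1C(=O)N1CCC(=O)CC1=O` in a functional assay on A549 cells (Homo sapiens) for inhibition, read by sulforhodamine B assay, with a stated time of 72 h (a higher number here means a weaker inhibitor, a lower number a stronger inhibitor), gives 4090 nM, the only number so far, as compound 2 `CCN(CC)CCNC(=O)Nc1sc(-c2ccc(Cl)cc2)c(-c2ccc(Cl)cc2)c1C(=O)NC1CC1` in this assay gives "not determined" (no result reported). Compound 3 `Nc1sc(-c2ccc(Cl)cc2)c(-c2ccc(Cl)cc2)c1C(=O)N1CCCCC1` differs from compound 1 by the change (piperidin-1-yl in place of 2,4-dioxopiperidin-1-yl on a carbonyl carbon). Within the data shown here, no measured pair shows a step of this kind, so its size in this assay is open; a move within the usual scatter, if anything toward a slightly stronger inhibitor, is expected. For compound 3 the estimate is 3000 nM, with a range of 800 nM to 12000 nM, an expected step of a 1.4-fold lower number from compound 1 to compound 3 (0.13 log units; within the scatter).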

Compound 3, half-maximal inhibitory concentration: 4620 nM
Compound 3: the middle estimate sits 1.5-fold (0.19 log units) below what was measured, and the stated range covers the measured number.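

In this assay, within the data shown here, the step of a 1.1-fold higher number from compound 1 to compound 3 (0.05 log units; within the scatter) for piperidin-1-yl in place of 2,4-dioxopiperidin-1-yl on a carbonyl carbon is the first that can be read at this position. In this single pair, the ring carbonyls of compound 1 can be removed with no change beyond the scatter. Nothing measured bears on why this is so.

Among these compounds, compound 2 has no number, so no step to it can be read. Open, from the compounds shown here alone, is whether a piperidine ring carrying a carboxylic acid or an amine, or an open-chain diethylamide, would leave the number unchanged at this position.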